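Removing an Amino Group: From Compound 3 to Compound 4

The source may report more compounds than this note shows. Statements on the series, on what has been measured and on what is new or still open speak of the compounds shown alone.

Measured so far in an assay for inhibition of Maternal embryonic leucine zipper kinase (Homo sapiens), read by Z'-LYTE, with a stated time of 1 h, tested at 10 uM; on this read-out higher numbers stand for more inhibition at the one concentration tested (going by the name of the read-out) and lower numbers for less inhibition:
compound 1, `Nc1nc2c(ncn2[C@@H]2O[C@H](COC(=O)c3cc[nH]c3)[C@@H](O)[C@H]2O)c(=O)[nH]1`, gives 87%
compound 2, `O=C(OC[C@H]1O[C@@H](n2cnc3c(=O)[nH]cnc32)[C@H](O)[C@@H]1O)c1cc[nH]c1`, gives 97%
compound 3, `Nc1nc2c(ncn2[C@@H]2O[C@H](COC(=O)c3ccc[nH]3)[C@@H](O)[C@H]2O)c(=O)[nH]1`, gives 96%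

Compound 3 stands second highest of these three numbers, with compound 2 nearest to it and compound 1 furthest, both within the usual scatter of such measurements. Compound 4, `O=C(OC[C@H]1O[C@@H](n2cnc3c(=O)[nH]cnc32)[C@H](O)[C@@H]1O)c1ccc[nH]1`, differs from compound 3 in one place: hydrogen in place of amino on an aromatic carbon. This same change has been measured once already, from compound 1 to compound 2, where it gave a number 10 percentage points higher from compound 1 to compound 2 (within the scatter). That step lies within the scatter, so no shift beyond the scatter is expected in this assay for this change either. The step is therefore estimated as a number 1 percentage points higher from compound 3 to compound 4 (within the scatter). Compound 4 is expected to give about 97%, most likely between 90% and 100%.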

Compound 4, a percentage reported as inhibition, at one concentration (the size of the read-out at that concentration, not a potency): 97%
The estimate for compound 4 equals the measured number at the digits printed; the measured number falls inside the stated range.
By their numbers in this assay, from the lowest: compounds 1, 3, 2 and 4 (each within the scatter of the next).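

In this assay, hydrogen in place of amino on the aromatic carbon between two ring nitrogen atoms has now been read on a second core (a number 1 percentage points higher from compound 3 to compound 4 (within the scatter)), and the two readings agree: the same change on two cores in this assay, a number 10 percentage points higher (within the scatter) from compound 1 to compound 2 and a number 1 percentage points higher (within the scatter) from compound 3 to compound 4, 9 percentage points apart, within the scatter of two such steps

The pyrrole change can also now be read on a second core, the one lacking the amino group (no change at the digits printed from compound 2 to compound 4 (within the scatter)): the same change on two cores in this assay, a number 9 percentage points higher (within the scatter) from compound 1 to compound 3 and no change at the digits printed (within the scatter) from compound 2 to compound 4, 9 percentage points apart, within the scatter of two such steps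

Neither change therefore moves the number beyond the scatter on either core.

Going by these compounds, whether a larger group at this carbon, such as a methylamino group or a carboxylic acid, would move the number remains open. A single-concentration read-out also leaves open whether these four compounds differ in potency.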